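Replacing 4-butoxyphenyl with 3-chlorophenyl in a cell assay

The compounds below may be only part of what the source reports. "The series", "measured", "known", "first", "only" and "open" are said of these compounds alone.

- compound 1 `O=C(NNc1ccc(F)cc1)c1ccc(NS(=O)(=O)c2cnc(O)nc2O)cc1` gives > 20000 nM (a limit, not a number)
- compound 2 `CCCCOc1ccc(C(=O)NNC(=O)c2ccc(NS(=O)(=O)c3cnc(O)nc3O)cc2)cc1` gives 14700 nM

For the measured compounds named here, both results come from a functional assay on SGC-7901 cells (Homo sapiens) for antiproliferative activity, read by MTT assay, with a stated time of 24 h (a lower number here means a stronger inhibitor, a higher number a weaker inhibitor), and only two compounds have been measured so far. Compound 1 reached only a limit, > 20000 nM, so it has no exact value. Going by the values given here, compound 2 therefore holds the only true number, 14700 nM, and this makes it the natural starting point for the next comparison.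

The next compound, compound 3 `O=C(NNC(=O)c1cccc(Cl)c1)c1ccc(NS(=O)(=O)c2cnc(O)nc2O)cc1`, keeps the shared core but carries 3-chlorophenyl in place of 4-butoxyphenyl on a carbonyl carbon in the structure. Among the compounds with values here, no measured pair shows what a swap of this kind does, so the only anchor is compound 2 at 14700 nM and no trend can be drawn. In this assay the expected change is a 1.1-fold lower number from compound 2 to compound 3 (0.02 log units; within the scatter) with no shift beyond the usual scatter expected in either direction. For compound 3 the estimated value is 14000 nM with an expected range from 5000 nM to 25000 nM.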

Compound 3, half-maximal inhibitory concentration: 8610 nM
For compound 3 the middle estimate is 1.6-fold (0.21 log units) above the measured one, and the stated range covers the measured number.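

In this assay, the change at this carbonyl carbon gives a 1.7-fold lower number from compound 2 to compound 3 (0.23 log units; within the scatter), so 3-chlorophenyl, a group with fewer heavy atoms and a chlorine but no oxygen, can take the place of 4-butoxyphenyl with no difference that stands clear of repeat measurements. For the compounds shown here, the other new comparison is a different kind of change, with (3-chlorophenyl)carbonyl in place of 4-fluorophenyl on an amine nitrogen, and it gives an at least 2.3-fold lower number from compound 1 to compound 3 (0.36 log units; beyond the scatter), the first step in this small set to pass beyond the scatter. That step has a firm end at compound 3 only, since its other end is a limit and not a number, so its true size is unknown: the limit of > 20000 nM in this assay, at which 1 of the 3 values shown sits.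

A single step at this carbonyl carbon sets no trend, and the compounds shown do not separate the role of the chlorine from that of the ring carrying it. On these data alone, it remains open whether a plain phenyl, a shorter alkoxy chain such as methoxy, or a ring bearing an amine or a carboxylic acid at this place would move the number beyond the scatter in either direction.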